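Replacing pyridin-2-yl with 1H-pyrazol-4-yl: expected inhibition

The source may report more compounds than this note shows. Statements on the series, on what has been measured and on what is new or still open speak of the compounds shown alone.

Every value below comes from an assay on CHO cells for displacement of a labelled ligand from adenosine receptor A1 (Homo sapiens), read by scintillation counting, tested at 10 uM; on this read-out higher numbers stand for more inhibition at the one concentration tested (going by the name of the read-out) and lower numbers for less inhibition.

Compound 1 `Cc1csc(N)c1C(=O)c1ccc(Cl)cc1` gives 1%.
Compound 2 `CC(C)Cc1csc(N)c1C(=O)c1ccc(Cl)cc1` gives 1%.
Compound 3 `CC(C)(C)Cc1c(-c2ccccn2)sc(N)c1C(=O)c1ccc(Cl)cc1` gives 1%.

Compound 3 sits in the same place as the other two: its value and those of compound 1 and compound 2 lie within the usual scatter of one another, so none of the three shows meaningful inhibition in this assay at the concentration tested.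

Compound 4 `CC(C)(C)Cc1c(-c2cn[nH]c2)sc(N)c1C(=O)c1ccc(Cl)cc1` is the next member of the series. It differs from compound 3 in one place: 1H-pyrazol-4-yl in place of pyridin-2-yl on an aromatic carbon.

Among the compounds with values here, only one measured step exists in this set, no change at the digits printed from compound 1 to compound 2 (within the scatter), and it concerns a different position on the shared core, an isopropyl in place of hydrogen on a saturated chain carbon. Within the data shown here, no measured step alters the group on the aromatic carbon next to the ring sulfur, so there is no direct guide to the present change. What the data do show is that three different decorations of the shared core all give values within the scatter of each other, with nothing rising above it.

On that basis compound 4 is expected to show no change at the digits printed from compound 3 to compound 4 (within the scatter), that is, no step beyond the scatter. The estimated value for compound 4 is 1%, with a range from 0% to 10%.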

Compound 4, a percentage reported as inhibition, at one concentration (the size of the read-out at that concentration, not a potency): 1%
Compound 4: the middle estimate sits on the measured number at the digits printed; the measured number falls inside the stated range.
By their numbers in this assay, from the lowest: compounds 1, 2, 3 and 4 (each within the scatter of the next).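

In this assay, within the data shown here, the group on the aromatic carbon next to the ring sulfur is varied for the first time, and 1H-pyrazol-4-yl in place of pyridin-2-yl gives no change at the digits printed from compound 3 to compound 4 (within the scatter) in this series. The swap replaces a six-membered aromatic ring with 1 hetero atom and 0 hydrogen-bond donors by a five-membered aromatic ring with 2 hetero atoms and 1 hydrogen-bond donor, so at this position neither the change of ring size nor the added donor comes with a step beyond the scatter, at least with the neopentyl group and the rest of compound 3 held constant. No measurement here offers an explanation for this result.

With compound 4 at 1% and the other three compounds within the scatter of it, the series shows no clear inhibition from which a drop could be seen, so these results cannot tell whether this position matters when inhibition is present. Still open, as far as these compounds go, is whether a quite different group at this position, such as a carboxylic acid, a primary amine or a longer alkyl chain, would give a value beyond the scatter of these four.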